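Changing the side group on the shared core

The source may report more compounds than this note shows. Statements on the series, on what has been measured and on what is new or still open speak of the compounds shown alone.

Measured so far:
Compound 1 `CCCCCCCc1cn(C(c2ccccc2)c2cc3cc(Br)ccc3nc2OC)nn1` — 16.6%
Compound 2 `COc1nc2ccc(Br)cc2cc1C(c1ccccc1)n1cc(CCO)nn1` — 19.8%

Both compounds were tested in an ADME assay on PANC-1 cells (Homo sapiens) for cytotoxicity, read by sulforhodamine B assay, with a stated time of 48 h, tested at 10 uM; a higher number here means more inhibition at the concentration tested (going by the name of the read-out), a lower number less inhibition. For the measured compounds named here, compound 2 gives 19.8%, the higher of the two numbers, while compound 1 gives 16.6%; the one known step, a number 3.2 percentage points higher from compound 1 to compound 2 (within the scatter), lies within the scatter, so the two cannot be ordered.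

Compound 3 `COc1nc2ccc(Br)cc2cc1C(c1ccccc1)n1cc(-c2ccccc2C(F)(F)F)nn1` is not yet measured. It differs from compound 2 by 2-(trifluoromethyl)phenyl in place of 2-hydroxyethyl on an aromatic carbon, on the aromatic carbon of the five-membered aromatic ring with 3 nitrogen. Going by the values given here, no measured step touches a change of this kind; the only step known concerns the end of the saturated chain, and it was within the scatter. The expectation therefore rests on the two values alone, and compound 3 is expected to give about 22%, between 8% and 40%, a step of a number 2.2 percentage points higher from compound 2 to compound 3 (within the scatter) from compound 2 that would not stand out from the scatter.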

Compound 3, a percentage reported as inhibition, at one concentration (the size of the read-out at that concentration, not a potency): 11.4%
For compound 3 the middle estimate is 10.6 percentage points above the measured one; measured number inside the range.
By their numbers in this assay, from the lowest: compounds 3, 1 and 2 (each within the scatter of the next).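

In this assay, putting 2-(trifluoromethyl)phenyl on the aromatic carbon of the five-membered aromatic ring with 3 nitrogen in place of 2-hydroxyethyl gives a number 8.4 percentage points lower from compound 2 to compound 3 (within the scatter) and, in place of heptyl, gives a number 5.2 percentage points lower from compound 1 to compound 3 (within the scatter) at the same position. For the compounds shown here, this position has now carried a chain with a hydroxy group, a plain chain and an aromatic ring, and even this change from chain to ring gives no step that stands clear of the scatter, so the three compounds cannot be put in order. Nothing available explains these numbers.

The compounds shown leave open whether an amine or a carboxylic acid on this carbon would give a number clearly apart from these three. They also leave open whether a plain phenyl ring, without the trifluoromethyl, would behave any differently from compound 3.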